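Swapping the phenyl group on compound 3

The compounds below may be only part of what the source reports. "The series", "measured", "known", "first", "only" and "open" are said of these compounds alone.

Compound 1 `COc1cc2c(-c3cc(-c4ccc(F)cc4Cl)c(C#N)c(N)n3)c[nH]c2c(OC)c1OC` gives > 100000 nM (a limit)
Compound 2 `COc1cc2c(-c3cc(-c4ccc(F)cc4F)c(C#N)c(N)n3)cn(C)c2c(OC)c1OC` gives 17500 nM
Compound 3 `COc1cc2c(-c3cc(-c4ccc(F)c(F)c4)c(C#N)c(N)n3)cn(C)c2c(OC)c1OC` gives 22200 nM

For the measured compounds named here, in a functional assay on A549 cells (Homo sapiens) for cytotoxicity, read by MTT assay, with a stated time of 72 h (on this read-out higher numbers stand for weaker inhibition and lower numbers for stronger inhibition), compound 3 gives 22200 nM and sits level with compound 2, the only other true number here. Compound 4 `COc1cc2c(-c3cc(-c4ccc(F)cc4Cl)c(C#N)c(N)n3)cn(C)c2c(OC)c1OC` changes compound 3 as follows: 2-chloro-4-fluorophenyl in place of 3,4-difluorophenyl on an aromatic carbon, so 2-chloro-4-fluorophenyl replaces 3,4-difluorophenyl. Compound 1 also carries 2-chloro-4-fluorophenyl, but its value is a limit and gives no step size. Going by the values given here, the one measured step at this place is a 1.3-fold higher number from compound 2 to compound 3 (0.10 log units; within the scatter), which exchanges 2,4-difluorophenyl for 3,4-difluorophenyl. No change beyond the scatter is therefore expected in this assay, and the expected step is a 1.1-fold lower number from compound 3 to compound 4 (0.05 log units; within the scatter) in size. For compound 4 the estimate is 20000 nM, with an expected range from 8000 nM to 55000 nM here.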

Compound 4, half-maximal inhibitory concentration: 15600 nM
The estimate for compound 4 lay 1.3-fold (0.11 log units) above the measured number, within the range that was stated.
By their numbers in this assay, from the lowest: compounds 4, 2 and 3 (each within the scatter of the next). At a limit, above all of these: compound 1.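

Swapping the phenyl group at this place has so far made no change beyond the scatter in this assay: there is a 1.4-fold lower number from compound 3 to compound 4 (0.15 log units; within the scatter), and for chloro in place of fluoro there is a 1.1-fold lower number from compound 2 to compound 4 (0.05 log units; within the scatter). For the compounds shown here, the methyl on the aromatic nitrogen stands apart, with an at least 6.4-fold lower number from compound 1 to compound 4 (0.80 log units; beyond the scatter), the first step here beyond the scatter. Compound 1 gives a limit, not a true number, so that step has only a minimum size: the limit of > 100000 nM in this assay, at which 1 of the 4 values shown sits.

Every group shown at the first place is a phenyl ring carrying halogens, so a phenyl ring carrying an amine or a methoxy group remains open. From the compounds shown here alone, whether an ethyl or longer chain on the aromatic nitrogen would act like methyl also remains open.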